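The source may report more compounds than this note shows. Statements on the series, on what has been measured and on what is new or still open speak of the compounds shown alone.

Measured so far:

Compound 1, `C#Cc1cncc(C#Cc2ccc3ncn(-c4ccnc(N)n4)c3c2)c1`: 63100 nM
Compound 2, `C#Cc1ccnc(C#Cc2ccc3ncn(-c4ccnc(N)n4)c3c2)c1`: 316 nM
Compound 3, `C=Cc1ccnc(C#Cc2ccc3ncn(-c4ccnc(N)n4)c3c2)n1`: 1580 nM

All three share one core and differ only in the aromatic ring hanging from the triple-bonded carbon. In an assay on Sf9 cells for inhibition of mitogen-activated protein kinase kinase kinase 14 variant S549D (Homo sapiens), with a stated time of 30 min, in the presence of a further agent that is not named here (a higher number here means a weaker inhibitor, a lower number a stronger inhibitor), compound 3 stands second highest of the three numbers: it sits a 5.0-fold higher number from compound 2 to compound 3 (0.70 log units; beyond the scatter) away from compound 2, and compound 1 lies far above it, as a 40-fold lower number from compound 1 to compound 3 (1.60 log units; beyond the scatter) shows.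

Compound 4, `C#Cc1cncc(C#Cc2ccc3ncn(-c4ccnc(N)n4)c3c2)n1`, has not yet been measured. Relative to compound 3 the change is a group of 8 heavy atoms (6 carbon, 2 nitrogen; one six-membered aromatic ring with 2 hetero atoms) in place of a group of 8 heavy atoms (6 carbon, 2 nitrogen; one six-membered aromatic ring with 2 hetero atoms), on a triple-bonded carbon. For the measured compounds named here, no measured pair makes exactly this swap, but the three measured steps show that exchanging this ring can move the number a great deal: a 200-fold lower number from compound 1 to compound 2 (2.30 log units; beyond the scatter) and a 40-fold lower number from compound 1 to compound 3 (1.60 log units; beyond the scatter) are both large, while a 5.0-fold higher number from compound 2 to compound 3 (0.70 log units; beyond the scatter) is modest. A step beyond the scatter therefore seems likely, and since two of the three measured rings give weaker numbers than compound 2, the expected direction is towards a higher number. For compound 4 the estimate is 12000 nM, within 1500 nM to 80000 nM, which would mean an expected step of a 7.6-fold higher number from compound 3 to compound 4 (0.88 log units; beyond the scatter).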

Compound 4, half-maximal inhibitory concentration: 6310 nM
The estimate for compound 4 lay 1.9-fold (0.28 log units) above the measured number, and the stated range covers the measured number.
By their numbers in this assay, from the lowest: compound 2; then compound 3; then compound 4; then compound 1.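

In this assay, two groups that match in heavy atoms and hetero atoms are still not interchangeable on this triple-bonded carbon (a 4.0-fold higher number from compound 3 to compound 4 (0.60 log units; beyond the scatter)). Moving to a ring with two hetero atoms lowers the number in one comparison (a 10-fold lower number from compound 1 to compound 4 (1.00 log units; beyond the scatter)) but raises it in another (a 20-fold higher number from compound 2 to compound 4 (1.30 log units; beyond the scatter)), and the rings with one hetero atom, in compound 1 and compound 2, sit at opposite ends of the order, so the hetero atom count alone does not rank these four. Nothing available here explains these steps.

The swap from the double bond to the triple bond comes together with a different ring, so the contribution of each remains unresolved. Going by these compounds, how an amine or a longer chain on this ring would shift the number also remains open.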